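A few compounds are considered here, and "the series" means these few. Any claim that something is new, unique, unknown or untested is made for them only; others in the source may bear on it.

Compound 1, `COc1ccc(C(=O)/C=C/c2cc3ccccc3[nH]c2=O)cc1`, gives 8760 nM in a functional assay on HOP-92 cells (Homo sapiens) for cytotoxicity, read by sulforhodamine B assay, with a stated time of 24 h; a lower number here means a stronger inhibitor of growth, a higher number a weaker inhibitor of growth.
Compound 2, `O=C(/C=C/c1cc2ccccc2[nH]c1=O)c1ccc(O)cc1`, gives 23200 nM in this assay.

Among the measured compounds shown here, of the two numbers measured so far, compound 2 holds the higher one, so it is the weaker growth inhibitor of the pair; the only measured step, a 2.6-fold higher number from compound 1 to compound 2 (0.42 log units; beyond the scatter), separates it from compound 1.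

Compound 3, `O=C(/C=C/c1cc2ccccc2[nH]c1=O)c1ccc(Cl)cc1`, has not yet been measured in this assay. It differs from compound 2 by chloro in place of hydroxy on an aromatic carbon.

For the measured compounds named here, only one measured step touches this part of the molecule: the change from compound 1 to compound 2 also altered the group on the same aromatic carbon, and it moved the number modestly, by a 2.6-fold higher number from compound 1 to compound 2 (0.42 log units; beyond the scatter). Going by the values given here, no measured compound carries a chloro group anywhere, so there is no direct guide to its effect. The reasonable expectation is that exchanging the hydroxy group again shifts the number by a step of similar size, most likely back toward the lower number of compound 1. Compound 3 is therefore estimated to give about 10000 nM, with a range from 3000 nM to 35000 nM. The expected step from the hydroxy compound to the chloro compound is a 2.3-fold lower number from compound 2 to compound 3 (0.37 log units; beyond the scatter).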

Compound 3, concentration for total growth inhibition: 50500 nM
Compound 3: the middle estimate sits 5.1-fold (0.70 log units) below what was measured; the whole stated range lies below it.
By their numbers in this assay, from the lowest: compound 1; then compound 2; then compound 3.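

Hydroxy turns out to be a middle case on this aromatic carbon rather than the worst of the groups tried: in this assay, replacing it with chloro gives a 2.2-fold higher number from compound 2 to compound 3 (0.34 log units; beyond the scatter), so the number moves further from that of compound 1. Methoxy now stands as the best of the three groups, as chloro in its place gives a 5.8-fold higher number from compound 1 to compound 3 (0.76 log units; beyond the scatter), the largest step in this small set, which makes compound 1 the strongest growth inhibitor here and compound 3 the weakest. Hydroxy counts one hydrogen-bond donor and one acceptor while chloro counts neither, but nothing available explains why the number rises with this change.

From the compounds shown here alone, whether an amine, a carboxylic acid, a methyl group or a longer chain such as ethoxy on this carbon would fall below compound 1, above compound 3 or somewhere between them stays open. Also open, going by these compounds, is whether the same order of methoxy, hydroxy and chloro would hold on another carbon of this ring or in other cell types.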